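A few compounds are considered here, and "the series" means these few. Any claim that something is new, unique, unknown or untested is made for them only; others in the source may bear on it.

Values in a functional assay on A549 cells (Homo sapiens), read by MTT assay, with a stated time of 72 h; a higher number here means a weaker inhibitor, a lower number a stronger inhibitor:
- Compound 1 `C#Cc1cn([C@@H]2O[C@H](CO)[C@@H](O)[C@H]2O)c2ncnc(SC)c12`: 140 nM
- Compound 2 `C#Cc1cn([C@@H]2O[C@H](CO)[C@@H](O)[C@H]2O)c2ncnc(NC)c12`: > 20000 nM (a limit)
- Compound 3 `Cc1ncnc2c1c(-c1cccs1)cn2[C@@H]1O[C@H](CO)[C@@H](O)[C@H]1O`: > 20000 nM (a limit)

Compound 3 gives no number, only a limit, and so sits at the limit of > 20000 nM in this assay, at which 2 of the 3 values shown sit. Compound 4 `C#Cc1cn([C@@H]2O[C@H](CO)[C@@H](O)[C@H]2O)c2ncnc(C)c12` differs from compound 3 by ethynyl in place of thiophen-2-yl on an aromatic carbon. Among the measured compounds shown here, no measured step covers this change directly. Compound 4 shares the ethynyl group with compound 1 and compound 2, and keeps the methyl group of compound 3.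

For the measured compounds named here, the one measured step is large: an at least 140-fold higher number from compound 1 to compound 2 (2.15 log units; beyond the scatter). From the compounds shown here alone, it shows that ethynyl alone does not secure a low number, so the outcome for compound 4 remains open. Still, compound 1 carries ethynyl and gives 140 nM, which supports expecting a large move to a lower number in this assay. The expected step is an at least 25-fold lower number from compound 3 to compound 4 (1.39 log units; beyond the scatter). For compound 4 the estimate is 800 nM, with an expected range of 60 nM to 15000 nM.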

Compound 4, half-maximal inhibitory concentration: 19200 nM
Beside the measured number, compound 4's estimate is 24-fold (1.38 log units) below it; the measured number lies above the stated range.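

In this assay, ethynyl on the shared core does not by itself bring a low number: methyl in place of methylsulfanyl gives a 140-fold higher number from compound 1 to compound 4 (2.14 log units; beyond the scatter). Among the methylsulfanyl, methylamino and methyl compounds sharing ethynyl, only methylsulfanyl in compound 1 goes with a low number, so the group at that site matters at least as much as ethynyl. Ethynyl in place of thiophen-2-yl gives an at least 1.0-fold lower number from compound 3 to compound 4 (0.01 log units; that floor lies within the scatter). Methyl in place of methylamino gives an at least 1.0-fold lower number from compound 2 to compound 4 (0.01 log units; that floor lies within the scatter). Neither of these two steps can be read as a change, since compound 3 and compound 2 each give only a limit: the limit of > 20000 nM in this assay, at which 2 of the 4 values shown sit.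

From the compounds shown here alone, whether a longer sulfur chain such as ethylsulfanyl, or a methoxy group, at the methylsulfanyl site would keep the low number of compound 1 remains open. Going by these compounds, it is also open whether thiophen-2-yl can stand in place of ethynyl on the core of compound 1.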